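The source may hold more compounds than are shown below. What is called first, only, known or untested is meant among the compounds shown, and "the series" means these compounds.

Measured so far:
- compound 1, `Cc1ccc2nc([C@H](CC3CCN(C(=O)C(C)C)CC3)N3C(=O)CN(c4ccc(Oc5ccccc5)cc4)C3=O)n(C)c2c1`: 35 nM
- compound 2, `CC(=O)N1CCC(C[C@@H](c2nc3ccccc3n2C)N2C(=O)CN(c3ccc(Oc4ccccc4)cc3)C2=O)CC1`: 740 nM
- compound 3, `CC(=O)N1CCC(C[C@@H](c2nc3cc(F)ccc3n2C)N2C(=O)CN(c3ccc(Oc4ccccc4)cc3)C2=O)CC1`: 8300 nM

All three were tested in an assay on isolated protein for antagonist activity at Bile acid receptor (Homo sapiens), read by TR-FRET and LanthaScreen; on this read-out lower numbers stand for stronger inhibition and higher numbers for weaker inhibition. Among the compounds with values here, compound 3 has the highest number of the three, that is the weakest inhibition; its nearest neighbour is compound 2, and the one step measured between compounds that differ in a single place, an 11-fold higher number from compound 2 to compound 3 (1.05 log units; beyond the scatter), is the change that separates them.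

Compound 4, `CC(C)C(=O)N1CCC(C[C@@H](c2nc3cc(F)ccc3n2C)N2C(=O)CN(c3ccc(Oc4ccccc4)cc3)C2=O)CC1`, has not yet been measured. It differs from compound 3 in one place: isopropyl in place of methyl on a carbonyl carbon. Within the data shown here, no measured step covers exactly this change. Compound 1, which carries the isopropylcarbonyl group, and compound 2, which carries the acetyl group, differ in a second place as well, so their two values can only hint at the direction; on these hints a moderate move towards stronger inhibition is expected, so that compound 4 is expected to show a 3.3-fold lower number from compound 3 to compound 4 (0.52 log units; beyond the scatter). The number for compound 4 in this assay is therefore estimated at 2500 nM, with a range from 800 nM to 8000 nM.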

Compound 4, half-maximal inhibitory concentration: 340 nM
Compound 4: middle estimate off by 7.4-fold (0.87 log units), on the high side; the measured number lies below the stated range.
By their numbers in this assay, from the lowest: compound 1; then compound 4; then compound 2; then compound 3.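

In this assay, isopropyl in place of methyl on the carbonyl carbon gives a 24-fold lower number from compound 3 to compound 4 (1.39 log units; beyond the scatter) in a pair that differs only there, so this position has a large effect on the number. The earlier pair carrying these two groups also differed in a second place and could only hint at this. With the isopropylcarbonyl group held constant, 5-fluoro-1-methyl-1H-benzimidazol-2-yl in place of 1,6-dimethyl-1H-benzimidazol-2-yl gives a 9.7-fold higher number from compound 1 to compound 4 (0.99 log units; beyond the scatter) and shows that the substituents on that ring system still count when this acyl group is present. Nothing available here explains why either step has the size it has.

From the compounds shown here alone, it remains open how far the trend runs on the carbonyl carbon, for example whether a cyclopropyl, a tert-butyl or a dimethylamino group there would lower the number further or raise it again. The compounds shown also leave open whether the isopropyl group brings a step of similar size on the ring system without the fluoro, where hydrogen stands in its place, or whether its size holds only for the fluorinated pair.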